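Series notes: a (6-hydroxyhexyl)oxy chain on compound 2

A few compounds are considered here, and "the series" means these few. Any claim that something is new, unique, unknown or untested is made for them only; others in the source may bear on it.

compound 1 `COc1ccc2nc(C)cc(NCc3cccc(N(C)C)c3)c2c1` gives 14000 nM
compound 2 `Cc1cc(NCc2ccc(F)cc2)c2ccccc2n1` gives 15400 nM
compound 3 `COc1ccc2c(NCc3ccc(F)cc3)cc(C)nc2c1` gives 10200 nM

In a functional assay on MCF-10A cells (Homo sapiens) for antiproliferative activity, with a stated time of 48 h (a lower number here means that less compound is needed, a higher number that more compound is needed for the effect), compound 2 at 15400 nM lies within the scatter of both compound 1 and compound 3, so the three values give no order.

Compound 4 `Cc1cc(NCc2ccc(F)cc2)c2cc(OCCCCCCO)ccc2n1` is related to compound 2 by a single change: (6-hydroxyhexyl)oxy in place of hydrogen on an aromatic carbon. In words, this is (6-hydroxyhexyl)oxy in place of hydrogen on an aromatic carbon.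

Among the measured compounds shown here, only one measured step bears on it: a 1.5-fold lower number from compound 2 to compound 3 (0.18 log units; within the scatter). That step also puts an oxygen-linked group in place of hydrogen on an aromatic carbon, and it stays within the scatter. For the measured compounds named here, compound 1 also carries a methoxy group, but no single-place step links it to compound 2. Going by the values given here, no measured compound carries a chain of this length, so the data do not show how such a chain behaves in this assay. The range is therefore kept wide, and no direction is firmly expected.

The estimated step is a 1.3-fold lower number from compound 2 to compound 4 (0.11 log units; within the scatter), so none beyond the scatter is expected. For compound 4 the expected value is 12000 nM, with an estimated range from 5000 nM to 30000 nM.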

Compound 4, half-maximal effective concentration: 8100 nM
For compound 4 the middle estimate is 1.5-fold (0.17 log units) above the measured one; the range from low to high includes it.
By their numbers in this assay, from the lowest: compounds 4, 3, 1 and 2 (each within the scatter of the next).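

On this aromatic carbon, meta to a fused ring and para to a fused ring, a chain as large as (6-hydroxyhexyl)oxy, with its 8 heavy atoms, gives a 1.9-fold lower number from compound 2 to compound 4 (0.28 log units; within the scatter) in this assay and so produces no readable change. Before this, the only single-place step from compound 2 was the much smaller methoxy, with a 1.5-fold lower number from compound 2 to compound 3 (0.18 log units; within the scatter) in this assay as its reading, so tolerance of a long chain with a hydroxyl at its end is new information for the series. Nothing available on these compounds accounts for this result.

The compounds shown leave open whether the terminal hydroxyl has any part in this reading, or whether a plain hexyl ether, an amine or a carboxylic acid at the chain end, or a longer chain would also stay within the scatter of compound 2. They also leave open whether any group on this carbon can move the number beyond the scatter in this assay at all, and how the same chain would read on the core of compound 1 or compound 3.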